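Piperidine in Place of Cyanopyridine on a Shared Core

The source may hold more compounds than are shown below. What is called first, only, known or untested is meant among the compounds shown, and "the series" means these compounds.

Measured so far, in a functional assay on HEK293 cells for agonist activity at Bombesin receptor subtype-3 (Homo sapiens), read by luminescence and calcium flux, with a stated time of 10 min; a lower number here means that less compound is needed, a higher number that more compound is needed for the effect:
Compound 1 `CCC(C)(C)Cc1c[nH]c(CCc2ccc(-c3cccc(C#N)n3)cc2)n1`: 95 nM
Compound 2 `c1ccc(-c2ccc(CCc3nc(CC4CCCC4)c[nH]3)cc2)nc1`: 98 nM
Compound 3 `CCC(C)(C)Cc1c[nH]c(CCc2ccc(-c3cnsc3)cc2)n1`: 100 nM

Compound 1 gives the lowest of the three numbers in this assay, yet compound 2 and compound 3 sit so close to it that no order among the three can be read. For the measured compounds named here, the one single-point step that has been measured, a 1.1-fold higher number from compound 1 to compound 3 (0.02 log units; within the scatter), exchanges one aromatic substituent for another on the same aromatic carbon and leaves the number essentially where it was. Going by the values given here, compound 2 differs from compound 1 in two places at once, so its value shows only that the shared core tolerates such variation.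

The unmeasured compound 4 `CCC(C)(C)Cc1c[nH]c(CCc2ccc(N3CCCCC3)cc2)n1` arises from compound 1 by piperidin-1-yl in place of 6-cyanopyridin-2-yl on an aromatic carbon. Here an aromatic ring gives way to a saturated ring bound through nitrogen, a kind of change none of the measured steps covers. The step of a 1.1-fold higher number from compound 1 to compound 3 (0.02 log units; within the scatter) suggests this position tolerates exchange, but it does not speak to the loss of aromaticity. Compound 4 is therefore expected to land at roughly 200 nM, between 60 nM and 800 nM, a step of a 2.1-fold higher number from compound 1 to compound 4 (0.32 log units; beyond the scatter) that is expected but uncertain.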

Compound 4, half-maximal effective concentration: 108 nM
For compound 4 the middle estimate is 1.9-fold (0.27 log units) above the measured one, within the range that was stated.
By their numbers in this assay, from the lowest: compounds 1, 2, 3 and 4 (each within the scatter of the next).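

In this assay the exchange of 6-cyanopyridin-2-yl for piperidin-1-yl gives a 1.1-fold higher number from compound 1 to compound 4 (0.06 log units; within the scatter) and the exchange of 1,2-thiazol-4-yl for the same group gives a 1.1-fold higher number from compound 3 to compound 4 (0.03 log units; within the scatter) and so leaves the number within the scatter both times. Among the compounds shown, this place on the six-membered aromatic ring of carbon only therefore accepts a six-membered non-aromatic ring as well as the two aromatic groups, and neither an aromatic ring nor a nitrile in the group at this place is needed to stay within the scatter of compound 1. Nothing available explains why these different groups give such similar numbers.

From the compounds shown here alone, whether a carboxylic acid, a primary amine or a single methyl group would be accepted at this place remains open. So does whether morpholine, or an open-chain amine such as diethylamino, would behave like piperidin-1-yl.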